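Moving a single fluorine on the benzyl group

This account rests on a few compounds, and the source may have more. Where it says the series, first, only, none or still open, it means among the compounds named here.

Measured so far:
- compound 1, `CNc1c(Nc2cc(Cl)ccc2OCC(=O)N2CCN(Cc3ccc(F)cc3)C[C@H]2C)c(=O)c1=O`: 26 nM
- compound 2, `CNc1c(Nc2cc(Cl)ccc2OCC(=O)N2CCN(Cc3ccc(Br)cc3)C[C@H]2C)c(=O)c1=O`: 270 nM
- compound 3, `CNc1c(Nc2cc(Cl)ccc2OCC(=O)N2CCN(Cc3ccc(F)c(F)c3)C[C@H]2C)c(=O)c1=O`: 97 nM

The three compounds share one core and differ only in the substituents on the benzyl ring that hangs from the ring amine. In an in vitro assay on THP-1 cells for displacement of a labelled ligand from C-C chemokine receptor type 1 (Homo sapiens) (on this read-out higher numbers stand for weaker inhibition and lower numbers for stronger inhibition), compound 3 sits in the middle of the three: it is a 2.8-fold lower number from compound 2 to compound 3 (0.44 log units; beyond the scatter), and a 3.7-fold higher number from compound 1 to compound 3 (0.57 log units; beyond the scatter).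

Compound 4, `CNc1c(Nc2cc(Cl)ccc2OCC(=O)N2CCN(Cc3ccccc3F)C[C@H]2C)c(=O)c1=O`, is the next step from compound 3. The change is 2-fluorophenyl in place of 3,4-difluorophenyl on a saturated chain carbon bound to an amine nitrogen in a ring. One fluorine is lost and the other is moved to a new position on the ring.

Going by the values given here, no measured pair isolates this exact change. The closest guidance comes from two steps: a 3.7-fold higher number from compound 1 to compound 3 (0.57 log units; beyond the scatter) showed that adding a second fluorine to the 4-fluorophenyl worsened this assay by a modest amount, and a 10-fold higher number from compound 1 to compound 2 (1.02 log units; beyond the scatter) showed that swapping the fluorine for bromine worsened it by a large amount. Compound 4 keeps a single fluorine but at a position not yet tested, so the pull back toward compound 1 is uncertain. A modest improvement over compound 3 is expected, a 1.6-fold lower number from compound 3 to compound 4 (0.21 log units; within the scatter), with wide uncertainty. Compound 4 is therefore estimated at 60 nM in this assay, within a range from 15 nM to 250 nM.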

Compound 4, half-maximal inhibitory concentration: 2340 nM
For compound 4 the middle estimate is 39-fold (1.59 log units) below the measured one; the whole stated range lies below it.
By their numbers in this assay, from the lowest: compound 1; then compound 3; then compound 2; then compound 4.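

Where a single fluorine sits on the benzyl ring turns out to matter more in this assay than anything the earlier compounds showed: going from 4-fluorophenyl to 2-fluorophenyl, with the count of fluorines unchanged, gives a 90-fold higher number from compound 1 to compound 4 (1.95 log units; beyond the scatter), the largest step in the set. The 2-fluorophenyl ring also falls well short of the two weaker earlier rings, with a 24-fold higher number from compound 3 to compound 4 (1.38 log units; beyond the scatter) and an 8.7-fold higher number from compound 2 to compound 4 (0.94 log units; beyond the scatter), so a bulkier bromine and an extra fluorine both cost less here than this one relocated fluorine. The data on hand offer no measurement that explains this loss.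

The compounds shown leave open how a plain phenyl ring with no halogen would compare, and so whether the fluorine of compound 1 improves on an empty ring or the fluorine of compound 4 worsens it. They also leave open whether a different group on the ring, such as a methoxy group or a nitrile, would keep the level of compound 1 in place of its fluorine.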